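The source may report more compounds than this note shows. Statements on the series, on what has been measured and on what is new or still open speak of the compounds shown alone.

Working notes on the series. Compound 1 is `CCN1CCN(CCCOc2cc3nccc(Oc4ccc(C5SCC(=O)N5NC(=O)Nc5ccc(F)cc5F)cc4F)c3cc2OC)CC1` and compound 2 is `COc1cc2c(Oc3ccc(C4SCC(=O)N4NC(=O)Nc4ccc(F)cc4F)cc3F)ccnc2cc1OCCCN1CCN(C)CC1`; they share one core and differ only at the chain-bound ring amine, where compound 1 carries a methyl and compound 2 a hydrogen. In a functional assay on A549 cells (Homo sapiens) for cytotoxicity, read by MTT assay, with a stated time of 72 h (on this read-out lower numbers stand for stronger inhibition and higher numbers for weaker inhibition), compound 1 gives 1000 nM. In this assay compound 2 gives 650 nM. Among the measured compounds shown here, the only step measured so far, a 1.5-fold lower number from compound 1 to compound 2 (0.19 log units; within the scatter), sits inside the usual scatter, so while compound 2 holds the lower of the two numbers, the two compounds are not separated by it.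

Compound 3 is `COc1cc2c(Oc3ccc(C4SCC(=O)N4NC(=O)Nc4ccc(F)cc4F)cc3F)ccnc2cc1OCCCN1CCCN(C)CC1`. Relative to compound 2 the change is 4-methyl-1,4-diazepan-1-yl in place of 4-methylpiperazin-1-yl on a saturated chain carbon, three bonds along the chain from an oxygen on an aromatic ring. For the measured compounds named here, no measured step alters this ring itself; the one step known, a 1.5-fold lower number from compound 1 to compound 2 (0.19 log units; within the scatter), touches only the substituent on the amine and moved the number little. With nothing beyond the scatter recorded at this end of the molecule, the expected outcome in this assay is a step no larger than the scatter, in no preferred direction, that is no change at the digits printed from compound 2 to compound 3 (within the scatter). The number for compound 3 is estimated at 650 nM, with a range from 250 nM to 1700 nM.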

Compound 3, half-maximal inhibitory concentration: 710 nM
Beside the measured number, compound 3's estimate is 1.1-fold (0.04 log units) below it; measured number inside the range.
By their numbers in this assay, from the lowest: compounds 2, 3 and 1 (each within the scatter of the next).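

In this assay, among the compounds shown here, the ring itself at this position now has a measured step: 4-methyl-1,4-diazepan-1-yl in place of 4-methylpiperazin-1-yl, on a saturated chain carbon three bonds along the chain from an oxygen on an aromatic ring, gives a 1.1-fold higher number from compound 2 to compound 3 (0.04 log units; within the scatter), whereas the one earlier step touched only the substituent on the ring amine. Against the 4-ethylpiperazin-1-yl group of compound 1, the same seven-membered ring gives a 1.4-fold lower number from compound 1 to compound 3 (0.15 log units; within the scatter), so neither change of ring separates compound 3 from the other two compounds, and the three terminal groups stay unresolved in this assay. No other data bear on this result, so it remains a bare observation from a single cell read-out.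

Open, on these data alone, is whether a terminal group outside this set, such as morpholin-4-yl or an open-chain dimethylamino group, would move the number beyond the scatter. Also open is how a shorter ethyl or a longer butyl chain carrying 4-methylpiperazin-1-yl would read in this assay, since every compound shown keeps the propyl chain.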